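Moving fluoro from 2-fluorophenyl to 4-fluorophenyl

The compounds below may be only part of what the source reports. "The series", "measured", "known", "first", "only" and "open" are said of these compounds alone.

In an ADME assay on microsomes from liver (Homo sapiens) for pharmacokinetics (a lower number here means slower removal, a higher number faster removal of the compound), compound 1 `Cc1ccc(S(=O)(=O)N[C@@H](CC(=O)NC(C)(C)C)C(=O)NCCNC(=O)c2ccccc2)cc1` gives 122 mL.min-1.g-1 and compound 2 `Cc1ccc(S(=O)(=O)N[C@@H](CC(=O)NC(C)(C)C)C(=O)NCCNC(=O)c2ccccc2F)cc1` gives 141 mL.min-1.g-1 which lies within the scatter of compound 1, so the two stand level. Compound 3 `Cc1ccc(S(=O)(=O)N[C@@H](CC(=O)NC(C)(C)C)C(=O)NCCNC(=O)c2ccc(F)cc2)cc1` differs from compound 2 by 4-fluorophenyl in place of 2-fluorophenyl on a carbonyl carbon with 4-fluorophenyl in place of 2-fluorophenyl on a carbonyl carbon. Going by the values given here, the only guide is the step of a 1.2-fold higher number from compound 1 to compound 2 (0.06 log units; within the scatter) for fluoro in place of hydrogen on an aromatic carbon, and it stayed within the scatter. No change beyond the scatter is therefore expected in this assay here. The expected step is a 1.1-fold lower number from compound 2 to compound 3 (0.04 log units; within the scatter) and no more. Compound 3 is estimated at 130 mL.min-1.g-1 with an expected range of 75 mL.min-1.g-1 to 220 mL.min-1.g-1 in this measure.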

Compound 3, intrinsic clearance in microsomes: 149 mL.min-1.g-1
Compound 3: the middle estimate sits 1.1-fold (0.06 log units) below what was measured; the measured number falls inside the stated range.
By their numbers in this assay, from the lowest: compounds 1, 2 and 3 (each within the scatter of the next).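

In this assay, the place of the fluoro group on the ring proves to matter as little here as its presence: moving it gives a 1.1-fold higher number from compound 2 to compound 3 (0.02 log units; within the scatter), and the 4-fluorophenyl group set against the phenyl of compound 1 gives a 1.2-fold higher number from compound 1 to compound 3 (0.09 log units; within the scatter). Neither fluorinated compound therefore separates from compound 1 in this measure. Nothing at hand accounts for this flat result. Still open, going by these compounds, is whether a chlorine atom, a methoxy group or an amine on this ring would shift the number, and whether changes elsewhere on the shared core would.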